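Adding a Carbamoyl-Bearing Amino Group to Compound 1

The source may report more compounds than this note shows. Statements on the series, on what has been measured and on what is new or still open speak of the compounds shown alone.

This account follows one step within a small set of compounds characterised in a physicochemical assay for lipophilicity, read by HPLC, at pH 7.5; on this read-out lower numbers stand for lower lipophilicity and higher numbers for higher lipophilicity. Compound 1 `CCOc1ccccc1-c1ccc(-c2nc3cnccc3cc2C#N)cc1` gives 3.8 in this assay, the highest of the three numbers in hand. Compound 2 `CC[C@@H](Nc1c(C#N)c(-c2ccc(-c3ccccc3F)cc2)nc2cnccc12)C(N)=O` gives 2.7, which lies beyond the scatter below compound 1. Compound 3 `CC(C)(CC(N)=O)c1c(C#N)c(-c2ccc(Br)cc2)nc2cnccc12` gives 2.1, the lowest of the three and also beyond the scatter below compound 1.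

The step examined here leads from compound 1 to compound 4 `CCOc1ccccc1-c1ccc(-c2nc3cnccc3c(N[C@H](CC(C)C)C(N)=O)c2C#N)cc1`. The difference between the two structures is (1-carbamoyl-3-methylbutyl)amino in place of hydrogen on an aromatic carbon. Compound 4 has not yet been measured in this assay.

Going by the values given here, no single-point step between measured compounds is available to guide the estimate. Compound 2 carries a related carbamoyl-bearing amino group on its core and gives 2.7, well below compound 1. On that basis the step of a number 0.70 log units lower from compound 1 to compound 4 (beyond the scatter) is expected to be a decrease beyond the scatter. Compound 4 is therefore estimated at 3.1, within a range from 2.5 to 3.7.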

Compound 4, distribution coefficient: 3.4
Estimate against measurement, compound 4: 0.30 log units below; measured number inside the range.
By their numbers in this assay, from the lowest: compound 3; then compound 2; then compound 4; then compound 1.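

In this assay, (1-carbamoyl-3-methylbutyl)amino in place of hydrogen on the aromatic carbon ortho to the cyano group and opposite the ring nitrogen gives a number 0.40 log units lower from compound 1 to compound 4 (beyond the scatter). Going by these compounds alone, this is the first direct reading at this position, as the earlier compounds offered no pair differing in one place, and it shows that an entering group of 9 heavy atoms with 2 hydrogen-bond donors moves the read-out by only a modest step. No measurement shown here accounts for the size of that step.

Which part of the entering group sets the step remains open, whether the carbamoyl, the branched chain or the defined stereocentre. A simple amine, a carboxylic acid in place of the carbamoyl or a shorter chain on this carbon would help separate these contributions.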